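Three measured compounds and a dichlorophenyl analogue to come

A few compounds are considered here, and "the series" means these few. Any claim that something is new, unique, unknown or untested is made for them only; others in the source may bear on it.

Compound 1 `COc1ccc(/C=N/c2c(C)n(C)n(-c3ccccc3)c2=O)cc1`: 977000000 nM
Compound 2 `COc1ccccc1/C=N/c1c(C)n(C)n(-c2ccccc2)c1=O`: 933000000 nM
Compound 3 `Cc1c(/N=C/c2ccccc2)c(=O)n(-c2ccccc2)n1C`: 933000000 nM

In a functional assay on DLD-1 cells (Homo sapiens) for cytotoxicity, read by MTT assay, with a stated time of 72 h (a higher number here means a weaker inhibitor, a lower number a stronger inhibitor), compound 1 gives 977000000 nM, compound 2 gives 933000000 nM and compound 3 gives 933000000 nM. The measured steps are a 1.0-fold lower number from compound 1 to compound 2 (0.02 log units; within the scatter), a 1.0-fold lower number from compound 1 to compound 3 (0.02 log units; within the scatter) and no change at the digits printed from compound 2 to compound 3 (within the scatter), so all three compounds sit within the scatter of one another, and compound 3 is level with compound 2 on the numbers shown. Compound 4 `Cc1c(/N=C/c2ccc(Cl)cc2Cl)c(=O)n(-c2ccccc2)n1C` carries 2,4-dichlorophenyl in place of phenyl on a carbon with a double bond to nitrogen. Among the measured compounds shown here, no measured step touches a chlorine, and every measured step on this core lies within the scatter, so the step is expected to be a 1.0-fold lower number from compound 3 to compound 4 (0.00 log units; within the scatter), with no direction beyond the scatter. Compound 4 is therefore estimated at 930000000 nM, within 400000000 nM to 1500000000 nM.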

Compound 4, half-maximal inhibitory concentration: 126000000 nM
Beside the measured number, compound 4's estimate is 7.4-fold (0.87 log units) above it, outside the stated range (below it).
By their numbers in this assay, from the lowest: compound 4; then compounds 2, 3 and 1 (each within the scatter of the next).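

In this assay the group on the carbon with a double bond to nitrogen now moves the number: 2,4-dichlorophenyl gives a 7.4-fold lower number from compound 3 to compound 4 (0.87 log units; beyond the scatter) against phenyl, a 7.4-fold lower number from compound 2 to compound 4 (0.87 log units; beyond the scatter) against 2-methoxyphenyl and a 7.8-fold lower number from compound 1 to compound 4 (0.89 log units; beyond the scatter) against 4-methoxyphenyl. Among the compounds shown here, earlier changes at this position stayed within the scatter, so this is the first change here that exceeds it. No measurement shown accounts for this step. The compounds shown leave open whether 2-chlorophenyl or 4-chlorophenyl alone would give such a step, and what an amine or a carboxylic acid on the phenyl group would do.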